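Compound 2 Pared Back by One Group

This account rests on a few compounds, and the source may have more. Where it says the series, first, only, none or still open, it means among the compounds named here.

Measured so far:
compound 1 `c1ccc2[nH]c(-c3ccc(-c4ccc(C5=NCCN5)cc4)o3)nc2c1` gives 8600 nM in a functional assay on B16 cells (Mus musculus), with a stated time of 72 h; on this read-out higher numbers stand for weaker inhibition and lower numbers for stronger inhibition
compound 2 `N=C(N)c1ccc(-c2ccc(-c3nc4cc(C(=N)N)ccc4[nH]3)o2)cc1` gives 43200 nM in this assay

Of the two numbers, compound 2 stands highest, and its nearest neighbour, compound 1, has a number that is clearly lower, so compound 2 is the weaker inhibitor of the pair. Compound 3 `N=C(N)c1ccc(-c2ccc(-c3nc4ccccc4[nH]3)o2)cc1` has not been measured yet. It differs from compound 2 in one place: a hydrogen atom in place of a group of 3 heavy atoms (1 carbon, 2 nitrogen; no ring), on an aromatic carbon. Compound 3 thereby keeps a single such group, as compound 1 keeps a single ring-closed relative of it, and compound 1 gives 8600 nM. The expectation is therefore a drop in the number, beyond the scatter, with the step from compound 2 to compound 3 estimated at a 3.6-fold lower number from compound 2 to compound 3 (0.56 log units; beyond the scatter). Compound 3 is expected to give about 12000 nM, within a range from 4000 nM to 40000 nM.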

Compound 3, half-maximal inhibitory concentration: 51400 nM
For compound 3 the middle estimate is 4.3-fold (0.63 log units) below the measured one; the whole stated range lies below it.
By their numbers in this assay, from the lowest: compound 1; then compounds 2 and 3 (each within the scatter of the next).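

In this assay, putting a hydrogen atom in place of the group of 3 heavy atoms (1 carbon, 2 nitrogen; no ring) on this aromatic carbon of the fused system gives a 1.2-fold higher number from compound 2 to compound 3 (0.08 log units; within the scatter), so this assay does not tell the two compounds apart. At this position, the group and a plain hydrogen atom are therefore indistinguishable on this read-out. The one-place change that does register lies elsewhere: a group of 3 heavy atoms (1 carbon, 2 nitrogen; no ring) in place of the five-membered non-aromatic ring group of compound 1 gives a 6.0-fold higher number from compound 1 to compound 3 (0.78 log units; beyond the scatter), and nothing measured on these compounds accounts for either step.

Still open, from the compounds shown here alone, is whether another group on the same aromatic carbon, such as an amine or a carboxylic acid, would move the number beyond the scatter. Also open, going by these compounds, is what the five-membered ring group would do at that position.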